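A few compounds are considered here, and "the series" means these few. Any claim that something is new, unique, unknown or untested is made for them only; others in the source may bear on it.

For the measured compounds named here, in a physicochemical assay for solubility, in phosphate buffer, measured as thermodynamic solubility, at pH 7.4 (on this read-out higher numbers stand for higher solubility and lower numbers for lower solubility), compound 2 (`CCS(=O)(=O)NC(=O)CCc1cn(-c2ccc(Br)cc2)nc1-c1ccc(Cl)cc1`) gives 10000 nM, the only actual number in this small set. Compound 1 (`CN(C(=O)CCc1cn(-c2ccc(Br)cc2)nc1-c1ccc(Cl)cc1)S(C)(=O)=O`) gives < 5000 nM, which is a limit of the assay and not a number. Going by the values given here, the one measured step is an at least 2.0-fold higher number from compound 1 to compound 2 (0.30 log units; that floor lies within the scatter). With only this bound to go on, compound 2 cannot be placed any more firmly.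

Compound 3 (`Clc1ccc(-c2nn(-c3ccc(Br)cc3)cc2CCc2nnn[nH]2)cc1`) differs from compound 2 by 1H-tetrazol-5-yl in place of (ethylsulfonyl)carbamoyl on a saturated chain carbon, two bonds along the chain from an aromatic carbon. Among the compounds with values here, the measured step varies the group that this change removes entirely, so it bears on the new change only weakly and offers no measured precedent for the group that enters. No shift beyond the scatter is therefore expected in this assay, and no direction can be favoured with confidence. The expected change is a 1.2-fold higher number from compound 2 to compound 3 (0.08 log units; within the scatter). Compound 3 is estimated at 12000 nM, with an expected range from 3000 nM to 50000 nM.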

Compound 3, solubility: 150000 nM
Estimate against measurement, compound 3: 13-fold (1.10 log units) below; the whole stated range lies below it.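

In this assay, the earlier step only exchanged one sulfonyl-bearing group for another, whereas here (ethylsulfonyl)carbamoyl leaves altogether and 1H-tetrazol-5-yl enters on the same saturated chain carbon, giving a 15-fold higher number from compound 2 to compound 3 (1.18 log units; beyond the scatter), although both groups count the same hydrogen-bond donors and acceptors. So this position responds strongly to a change of group type, and the comparison across the other sulfonyl-bearing group points the same way, with an at least 30-fold higher number from compound 1 to compound 3 (1.47 log units; beyond the scatter). Compound 1 carries a limit and not a number, so that step is only a floor: the limit of < 5000 nM in this assay, at which 1 of the 3 values shown sits.

The compounds shown leave open whether a carboxylic acid on the same chain carbon would match compound 3 or stay close to compound 2. They also leave open whether the 1H-tetrazol-5-yl would hold its standing on a longer chain.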